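This account rests on a few compounds, and the source may have more. Where it says the series, first, only, none or still open, it means among the compounds named here.

Measured in a functional assay on HCT-116 cells (Homo sapiens), read by MTT assay, with a stated time of 72 h; a higher number here means a weaker inhibitor, a lower number a stronger inhibitor:
- compound 1 `Nc1nc(N)c2c(-c3ccco3)cn([C@@H]3O[C@H](CO)[C@@H](O)[C@H]3O)c2n1`: > 20000 nM
- compound 2 `Cc1nc(N)c2c(-c3ccoc3)cn([C@@H]3O[C@H](CO)[C@@H](O)[C@H]3O)c2n1`: > 20000 nM
- compound 3 `COc1nc(N)nc2c1c(-c1ccco1)cn2[C@@H]1O[C@H](CO)[C@@H](O)[C@H]1O`: > 20000 nM

Compound 3 gives only a limit, > 20000 nM, and not a number. The other two entries are limits as well, so no firm value exists to anchor a comparison.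

Compound 4 `COc1nc(N)nc2c1c(-c1ccccc1)cn2[C@@H]1O[C@H](CO)[C@@H](O)[C@H]1O` has phenyl in place of furan-2-yl on an aromatic carbon of the shared core: phenyl in place of furan-2-yl on an aromatic carbon.

Going by the values given here, the one measured step is a step that the two limits leave unreadable from compound 1 to compound 3. It is a different change, methoxy in place of amino on an aromatic carbon, and it offers no size to carry over.

Because (the limit of > 20000 nM in this assay, at which 3 of the 3 values shown sit), including compound 3, no step beyond the scatter is expected in this assay, and compound 4 is expected to return a limit too. The estimated change is a number no higher from compound 3 to compound 4 (the limit leaves the size open), with no direction expected. For compound 4 the estimate is 20000 nM, with an expected range of 8000 nM to 40000 nM.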

Compound 4, half-maximal inhibitory concentration: > 20000 nM
Compound 4 was reported as a limit; the forecaster's own chance of this, stated with the estimate: 80%; the middle value sits exactly at the limit.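

Compound 4, like compound 3, is reported only as a limit in this assay, so the step from furan-2-yl to phenyl cannot be read. The compounds shown leave open whether any change on the shared core would give a firm number: the limit of > 20000 nM in this assay, at which 4 of the 4 values shown sit.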